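Bromo for fluoro on the aryl urea of compound 2

The compounds below may be only part of what the source reports. "The series", "measured", "known", "first", "only" and "open" are said of these compounds alone.

Measured compounds:
Compound 1, `CCc1ccccc1NC(=O)N[C@H](C)c1ccccc1`: 92%
Compound 2, `C[C@@H](NC(=O)Nc1ccccc1F)c1ccccc1`: 77%

In an ADME assay on the whole organism with Oryza sativa as the target, tested at 10 uM (a higher number here means a weaker effect of the compound at the concentration tested, a lower number a stronger effect), compound 1 gives 92%, while compound 2 gives 77%. For the measured compounds named here, compound 2 thus holds the lower of the two numbers, and the one measured step, a number 15 percentage points lower from compound 1 to compound 2 (beyond the scatter), separates it from compound 1.

Compound 3, `C[C@@H](NC(=O)Nc1ccccc1Br)c1ccccc1`, has not yet been measured in this assay. It differs from compound 2 in one place: bromo in place of fluoro on an aromatic carbon. Going by the values given here, no measured step covers an exchange of one halogen for another; the only step known, a number 15 percentage points lower from compound 1 to compound 2 (beyond the scatter), concerns a different pair of groups at the same place. Because the step of a number 15 percentage points lower from compound 1 to compound 2 (beyond the scatter) was modest, the step from compound 2 to compound 3 is expected to be small, a number 6 percentage points higher from compound 2 to compound 3 (within the scatter), with direction uncertain. The estimate for compound 3 in this assay is 83%, between 68% and 95%.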

Compound 3, a percentage reported as activity, at one concentration (the size of the read-out at that concentration, not a potency): 94%
Compound 3: the middle estimate sits 11 percentage points below what was measured, and the stated range covers the measured number.
By their numbers in this assay, from the lowest: compound 2; then compounds 1 and 3 (each within the scatter of the next).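

In this assay, the place on the aromatic carbon turns out to be sensitive to which halogen it carries, with a number 17 percentage points higher from compound 2 to compound 3 (beyond the scatter). Bromo and ethyl cannot be told apart here, with a number 2 percentage points higher from compound 1 to compound 3 (within the scatter), so among the three groups at this place only fluoro stands apart, and the lower number of compound 2 is not shared by both halogens. No measured evidence bears on why fluoro and bromo differ at this place.

The compounds shown leave open whether chloro or methyl at this place would read like fluoro or like bromo and ethyl. They also leave open whether a methoxy group or an amine here would give a number lower than that of compound 2, which is 77%.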